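A few compounds are considered here, and "the series" means these few. Any claim that something is new, unique, unknown or untested is made for them only; others in the source may bear on it.

Working notes on the series. Compound 1 `Cn1c(-c2cccs2)nnc1[S+](C)[O-]` and compound 2 `Cn1c(-c2cccs2)nnc1S(C)(=O)=O` share one core; compound 3 `COc1ccc(-c2nnc([S+](C)[O-])n2C)cc1` and the not yet measured compound 4 `COc1ccc(-c2nnc(S(C)(=O)=O)n2C)cc1` share another. The difference between the two cores is not broken down here.

In a functional assay on the whole organism for antagonist activity, with Mus musculus as the target, in the maximal electroshock model (a higher number here means that more compound is needed for the effect, a lower number that less compound is needed), compound 1 gives > 200 mg/kg, which is a limit of the assay and not a number. In this assay compound 2 gives > 200 mg/kg, again a limit. In this assay compound 3 gives > 100 mg/kg, also a limit.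

The change from compound 1 to compound 2 is a group of 4 heavy atoms (1 carbon, 2 oxygen, 1 sulfur; no ring) in place of a group of 3 heavy atoms (1 carbon, 1 oxygen, 1 sulfur; no ring), on an aromatic carbon. The step it made, a step that the two limits leave unreadable from compound 1 to compound 2, cannot be read because the limit of > 200 mg/kg in this assay, at which 2 of the 3 values shown sit, holds both values.

The same kind of change leads from compound 3 to compound 4: a group of 4 heavy atoms (1 carbon, 2 oxygen, 1 sulfur; no ring) in place of a group of 3 heavy atoms (1 carbon, 1 oxygen, 1 sulfur; no ring), on an aromatic carbon. The surroundings differ in the group borne by the ring atom two ring bonds from the changed carbon, as the two structures show.

For compound 4 the expected step is a step that the limit leaves unreadable from compound 3 to compound 4, resting on compound 3 sitting at the limit of > 100 mg/kg in this assay, at which 1 of the 3 values shown sits, and on compound 1 and compound 2 both sitting at the limit of > 200 mg/kg in this assay, at which 2 of the 3 values shown sit. Compound 4 is estimated at 200 mg/kg, expected within 100 mg/kg to 400 mg/kg, most likely reported only as a limit.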

Compound 4, dose for half-maximal effect: > 200 mg/kg
Compound 4: no number, only a limit; the forecaster's own chance of this, stated with the estimate: 85%; the middle value lies on the limit itself.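

In this assay no step can be read between compound 3 and compound 4, as both results are limits of the assay and not numbers. The compounds shown leave open what dose any of the four needs for the effect, and so whether methylsulfonyl in place of the group it replaces shifts that dose on either core.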